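A few compounds are considered here, and "the series" means these few. Any claim that something is new, unique, unknown or untested is made for them only; others in the source may bear on it.

Compound 1, `Nc1nc2cc(-c3nn(CCCC(=O)NO)c4ncnc(N)c34)ccc2o1`: 19500 nM
Compound 2, `Nc1nc2cc(-c3nn(CCC(=O)NO)c4ncnc(N)c34)ccc2o1`: > 50000 nM (a limit of the assay)
Compound 3, `Nc1nc2cc(-c3nn(CCCCCCCCC(=O)NO)c4ncnc(N)c34)ccc2o1`: 30300 nM

In a functional assay on MDA-MB-231 cells (Homo sapiens) for inhibition, read by MTT assay, with a stated time of 72 h (on this read-out higher numbers stand for weaker inhibition and lower numbers for stronger inhibition), compound 3 gives 30300 nM, the higher of the two numbers shown. Its nearest neighbour is compound 1, and the step of a 1.6-fold higher number from compound 1 to compound 3 (0.19 log units; within the scatter) lies within the scatter. Compound 2 reaches only a limit of this assay, > 50000 nM, so it contributes no number.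

Compound 4, `Nc1nc2cc(-c3nn(CCCCCCC(=O)NO)c4ncnc(N)c34)ccc2o1`, is not yet measured. Its difference from compound 3 is this: hydroxycarbamoyl in place of 2-(hydroxycarbamoyl)ethyl on a saturated chain carbon, six bonds along the chain from an aromatic nitrogen

The measured steps that change the chain are the shortening an at least 2.5-fold higher number from compound 1 to compound 2 (0.40 log units; beyond the scatter), which weakens inhibition beyond the scatter, and the lengthenings a 1.6-fold higher number from compound 1 to compound 3 (0.19 log units; within the scatter) and an at least 1.6-fold lower number from compound 2 to compound 3 (0.21 log units; that floor lies within the scatter), both within the scatter. The chain of compound 4 is longer than that of compound 1 and shorter than that of compound 3, and across that range the numbers shown differ little. For compound 4 the expected step is therefore a 1.2-fold lower number from compound 3 to compound 4 (0.08 log units; within the scatter), no change beyond the scatter. Compound 4 is expected to give about 25000 nM, between 12000 nM and 50000 nM.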

Compound 4, half-maximal inhibitory concentration: 8430 nM
The estimate for compound 4 lay 3.0-fold (0.47 log units) above the measured number; the measured number lies below the stated range.
By their numbers in this assay, from the lowest: compound 4; then compounds 1 and 3 (each within the scatter of the next). At a limit, above all of these: compound 2.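

In this assay, the shorter chain of compound 4 brings the number down beyond the scatter (a 3.6-fold lower number from compound 3 to compound 4 (0.56 log units; beyond the scatter)), and it also does so against a still shorter chain (a 2.3-fold lower number from compound 1 to compound 4 (0.36 log units; beyond the scatter)). Chain length at this position is therefore not as flat as compounds 1 and 3 alone suggested: among the compounds shown, the lowest number sits at the chain of compound 4, with shorter and longer chains giving higher numbers (an at least 5.9-fold lower number from compound 2 to compound 4 (0.77 log units; beyond the scatter)). That last step is only a floor, as compound 2 gives a limit and not a number: the limit of > 50000 nM in this assay, at which 1 of the 4 values shown sits.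

Chains closer in length to that of compound 4, on either side, remain open, so the best length is not fixed. From the compounds shown here alone, whether a carboxylic acid or an amine at the end of the chain in place of hydroxycarbamoyl would keep the lower number is also open.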